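Benzoyl for the carbamate-bearing acyl group in the tellurium series

The compounds below may be only part of what the source reports. "The series", "measured", "known", "first", "only" and "open" are said of these compounds alone.

Compound 1 `COc1ccc(N(CC(=O)NCCC[Te]c2ccccc2)C(=O)CNC(=O)OC(C)(C)C)cc1` has been tested in a functional assay on SNB-19 cells (Homo sapiens) for inhibition, with a stated time of 48 h; a higher number here means that more compound is tolerated, a lower number that less compound is tolerated. For compound 1 the result is a limit of the assay and not a number, < 100000 nM. Among the measured compounds shown here, the only evidence on where compound 1 stands is the limit of < 100000 nM in this assay, at which 1 of the 3 values shown sits. Compound 2 `COc1ccc(N(CC(=O)NCCC[Te]c2ccccc2)C(=O)CCSC2=C(C)C(=O)c3ccccc3C2=O)cc1` gives 56200 nM in this assay, and compound 3 `CC1=C(SCCC(=O)OCC(=O)NCCC[Te]c2ccccc2)C(=O)c2ccccc2C1=O` gives 42700 nM. Compound 4 `COc1ccc(N(CC(=O)NCCC[Te]c2ccccc2)C(=O)c2ccccc2)cc1` is not yet measured. It differs from compound 1 by phenyl in place of ((tert-butoxycarbonyl)amino)methyl on a carbonyl carbon, in words phenyl in place of ((tert-butoxycarbonyl)amino)methyl on a carbonyl carbon. For the measured compounds named here, no step between two measured compounds is available for comparison, so the direction of this change rests on no measured precedent. Compound 4 is expected to give 60000 nM in this assay, within 20000 nM to 150000 nM. The expected step that the limit leaves unreadable from compound 1 to compound 4 is estimated as small, since compound 1 is known only as a limit.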

Compound 4, concentration lethal to 50% of the cells: < 100000 nM
Compound 4: a limit, no number (the forecaster's own chance of this, stated with the estimate: 35%); the middle value does not contradict the limit.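

Among the compounds shown here, compound 1 and compound 4 both stand as limits of the assay in this assay, not numbers, so no step between them can be read. The compounds shown leave open whether phenyl in place of ((tert-butoxycarbonyl)amino)methyl on a carbonyl carbon shifts the lethal concentration at all.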